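The source may hold more compounds than are shown below. What is called first, only, known or untested is meant among the compounds shown, and "the series" means these compounds.

Working notes on the series. Going by the values given here, in a functional assay on the whole organism (strain albino) with Mus musculus as the target, with a stated time of 0.5 h (on this read-out lower numbers stand for an effect already at smaller amounts and higher numbers for an effect only at larger amounts of compound), compound 1 `COc1ccc(C2CC(Nc3nc4ccc(Cl)cc4s3)=NN2C(C)=O)cc1O` gives 132 umol/kg, and this is the only number available so far. Its position within the series therefore cannot be ranked. Compound 2 `CC(=O)N1N=C(Nc2nc3ccc(Cl)cc3s2)CC1c1ccccc1` offers no comparison, with the entry "not determined" (no result reported).

The next compound to be measured is compound 3 `COc1ccc(C2CC(Nc3nc4ccc(C)cc4s3)=NN2C(C)=O)cc1O`. It keeps the core of compound 1 and changes it in one place: methyl in place of chloro on an aromatic carbon.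

Among the compounds with values here, no measured pair shows what such a replacement does in this assay, so the expectation stays close to the one measured compound. The expected change, a 1.1-fold higher number from compound 1 to compound 3 (0.03 log units; within the scatter), is none beyond the usual scatter, with no direction favoured. For compound 3 the estimated value is 140 umol/kg. The expected range for compound 3 runs from 50 umol/kg to 400 umol/kg.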

Compound 3, dose for half-maximal effect: 75.6 umol/kg
The estimate for compound 3 lay 1.9-fold (0.27 log units) above the measured number; low and high end bracket the measured number.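

In this assay, going by these compounds alone, the exchange of chloro for methyl on this aromatic carbon of the shared core gives a 1.7-fold lower number from compound 1 to compound 3 (0.24 log units; within the scatter) and is the first step that can be read. Compounds 1 and 3 therefore cannot be told apart on this read-out, and on this core the position accepts either group without a change beyond the scatter. No supporting data bear on this result, so the step stays a bare observation.

The compounds shown leave open whether any group at this position moves the number beyond the scatter, for example trifluoromethyl, an amine, a carboxylic acid or a longer chain such as propyl. They also leave open whether the same exchange behaves alike on a different core.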